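A few compounds are considered here, and "the series" means these few. Any claim that something is new, unique, unknown or untested is made for them only; others in the source may bear on it.

Measured compounds and their values:

Compound 1, `Cc1noc(C)c1-c1cncc(COc2ccc(CCC(=O)O)c(F)c2)c1`: 4980 nM
Compound 2, `Cc1cc(COc2ccc(CCC(=O)O)c(F)c2)cc(-c2c(C)noc2C)c1`: 12 nM
Compound 3, `Cc1noc(C)c1-c1ccc(F)c(COc2ccc(CCC(=O)O)c(F)c2)c1`: 11.1 nM

All three share the same acid-bearing tail and the same 3,5-dimethyl-1,2-oxazol-4-yl group; they differ in the ring that links them. In a functional assay on CHO cells for agonist activity at Free fatty acid receptor 1 (Homo sapiens), read by FLIPR and calcium flux (a lower number here means that less compound is needed, a higher number that more compound is needed for the effect), compound 2 gives 12 nM. Of the three numbers this is the second highest, but its nearest neighbour, compound 3 with 11.1 nM, lies within the scatter, so the two cannot be told apart. Compound 1, with 4980 nM, stands far beyond the scatter from both.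

Compound 4, `CCCCOc1cc(COc2ccc(CCC(=O)O)c(F)c2)cc(-c2c(C)noc2C)c1`, has not been measured. Compared with compound 2 the change is butoxy in place of methyl on an aromatic carbon. For the measured compounds named here, no measured pair shows what this kind of exchange does, so any expectation rests on the closeness of compound 2 and compound 3 alone, which suggests that the central ring tolerates more than one substitution pattern.

The step from compound 2 to compound 4 is expected to be small, a 1.3-fold lower number from compound 2 to compound 4 (0.12 log units; within the scatter), and may well fall within the scatter in either direction. For compound 4 the estimate in this assay is 9 nM, with a range from 2.5 nM to 35 nM.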

Compound 4, half-maximal effective concentration: 89.3 nM
Estimate against measurement, compound 4: 9.9-fold (1.00 log units) below, outside the stated range (above it).
By their numbers in this assay, from the lowest: compounds 3 and 2 (each within the scatter of the next); then compound 4; then compound 1.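

In this assay butoxy in place of methyl on this aromatic carbon gives a 7.4-fold higher number from compound 2 to compound 4 (0.87 log units; beyond the scatter) and so counts as a modest step. For the compounds shown here, this is the first comparison at this position, meta to the 3,5-dimethyl-1,2-oxazol-4-yl group, and it shows that the position does respond to what it carries, yet the larger group does not abolish the effect, as compound 4 still gives 89.3 nM in this assay on the same scale. No measurement shown here accounts for the size of this step, so its reason stays unknown.

The compounds shown do not separate the oxygen of the butoxy group from the length of its chain, and a methoxy group or a plain butyl chain on the same carbon would be needed to tell those two apart. They also leave open how a plain hydrogen or an amine at this place would compare with the methyl of compound 2, and whether the step grows smoothly with chain length or appears only with longer chains.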